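The source may hold more compounds than are shown below. What is called first, only, known or untested is meant among the compounds shown, and "the series" means these compounds.

Within the data shown here, in a functional assay on SK-BR-3 cells (Homo sapiens) for antiproliferative activity, read by CCK-8 assay, with a stated time of 72 h (on this read-out lower numbers stand for stronger inhibition and higher numbers for weaker inhibition), compound 1 `Cc1cc(Nc2cc(N3CCN(C)CC3)nc(Nc3ccc([N+](=O)[O-])cc3)n2)n[nH]1` gives 437 nM, the lowest of the two numbers so far, while compound 2 `Cc1cc(Nc2cc(N3CCN(C)CC3)nc(Nc3ccc(C#N)cc3)n2)n[nH]1` gives 883 nM. Compound 3 `COc1ccc(Nc2nc(Nc3cc(C)[nH]n3)cc(N3CCN(C)CC3)n2)cc1` remains unmeasured. Its difference from compound 1 is methoxy in place of nitro on an aromatic carbon. Among the measured compounds shown here, one measured step bears on this, also with nitro leaving at that place: a 2.0-fold higher number from compound 1 to compound 2 (0.31 log units; beyond the scatter), modest and just beyond the scatter. A step of similar size toward a higher number is therefore expected in this assay, namely a 1.8-fold higher number from compound 1 to compound 3 (0.26 log units; within the scatter). Compound 3 is estimated at 800 nM, with an expected range of 300 nM to 2200 nM.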

Compound 3, half-maximal inhibitory concentration: 14700 nM
Compound 3: the middle estimate sits 18-fold (1.26 log units) below what was measured; the measured number lies above the stated range.
By their numbers in this assay, from the lowest: compound 1; then compound 2; then compound 3.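

The place para to a large group on the aromatic ring proves far more sensitive than the cyano and nitro pair suggested: in this assay, methoxy gives a 34-fold higher number from compound 1 to compound 3 (1.53 log units; beyond the scatter) and a 17-fold higher number from compound 2 to compound 3 (1.22 log units; beyond the scatter). Both steps are large, so methoxy stands well apart from nitro and cyano, which differ only modestly. Nothing at hand accounts for this gap. Still open, going by these compounds, is whether methoxy alone produces this loss or whether other groups share it. An amine, a carboxylic acid or a chlorine atom at this place would help to settle that.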